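Removing the trifluoromethyl from a non-toxic pyrazole amide

This account rests on a few compounds, and the source may have more. Where it says the series, first, only, none or still open, it means among the compounds named here.

The two measured compounds, compound 1 `O=C(Nc1cccc(-n2cc(-c3ccncc3)c(-c3ccc(Cl)c(O)c3)n2)c1)Nc1ccc(Cl)c(Cl)c1` and compound 2 `COc1cc(-c2nn(-c3cccc(NC(=O)c4cccc(C(F)(F)F)c4)c3)cc2-c2ccncc2)ccc1Cl`, were tested in a functional assay on Malme-3M cells (Homo sapiens) for inhibition, read by sulforhodamine B assay, with a stated time of 48 h; on this read-out higher numbers stand for lower toxicity in this test and lower numbers for higher toxicity in this test. In this assay compound 1 reaches only the limit of the test, > 32500 nM. In this assay compound 2 likewise reaches only a limit, > 50000 nM. So compound 2 stands on no number at all: its value is a limit, and the one other value shown is a limit as well, as the lines the limit of > 32500 nM in this assay, at which 1 of the 2 values shown sits, and the limit of > 50000 nM in this assay, at which 1 of the 2 values shown sits, record. Within the data shown here, no step between measured compounds is available, so no measured step can guide the next change.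

Compound 3 `COc1cc(-c2nn(-c3cccc(NC(=O)c4ccccc4)c3)cc2-c2ccncc2)ccc1Cl` is not yet measured. It differs from compound 2 in one place: hydrogen in place of trifluoromethyl on an aromatic carbon. With both measured values sitting at limits, a step from compound 2 to compound 3 in this assay is expected to be small or none beyond the scatter, in no clear direction. Compound 3 is therefore estimated in this assay at 50000 nM, within 20000 nM to 100000 nM, and the step this estimate means is a number no higher from compound 2 to compound 3 (the limit leaves the size open); most likely the test again reports only a limit.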

Compound 3, concentration lethal to 50% of the cells: > 100000 nM
Compound 3: no number, only a limit (the forecaster's own chance of this, stated with the estimate: 80%); at least 2.0-fold (0.30 log units) between middle value and limit.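

In this assay compound 3 again reaches only a limit, > 100000 nM. Compound 2 also stands at a limit, so no step can be read between compound 2 and compound 3. The compounds shown leave open at what concentration any of them becomes toxic to these cells, and whether replacing trifluoromethyl with hydrogen changes that concentration at all.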